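Acrylamide tail change on compound 1: piperidinyl enamide

The source may report more compounds than this note shows. Statements on the series, on what has been measured and on what is new or still open speak of the compounds shown alone.

Working notes. Compound 1 `COc1cc2ncnc(N3CCCc4ccccc43)c2cc1NC(=O)C=C(C)C` gives 5410 nM in a functional assay on A549 cells (Homo sapiens) for antiproliferative activity, read by MTT assay, with a stated time of 72 h (a lower number here means a stronger inhibitor, a higher number a weaker inhibitor), the second highest of the three numbers in hand. Compound 2 `CC(C)=CC(=O)Nc1cc2c(N3CCCc4ccccc43)ncnc2cc1O[C@@H]1CCOC1` gives 7910 nM, and the step of a 1.5-fold higher number from compound 1 to compound 2 (0.16 log units; within the scatter) lies within the scatter. Compound 3 `O=C(/C=C/CN1CCCC1)Nc1cc2c(N3CCc4ccccc43)ncnc2cc1O[C@@H]1CCOC1` gives 2230 nM, the lowest number of the three, but it differs from compound 1 in more than one place, so its value alone is what it shows. Compound 4 `COc1cc2ncnc(N3CCCc4ccccc43)c2cc1NC(=O)/C=C/CN1CCCCC1` is compound 1 with 3-(piperidin-1-yl)prop-1-en-1-yl in place of 2-methylprop-1-en-1-yl on a carbonyl carbon. Among the compounds with values here, no measured step changes only this group; the single pointer is that compound 3, the closest measured analogue of the entering group, gives 2230 nM. The expected step is therefore a 2.2-fold lower number from compound 1 to compound 4 (0.34 log units; beyond the scatter), a modest move toward a lower number. Compound 4 is estimated at 2500 nM, with a range of 1000 nM to 6500 nM.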

Compound 4, half-maximal inhibitory concentration: 2880 nM
Beside the measured number, compound 4's estimate is 1.2-fold (0.06 log units) below it, within the range that was stated.
By their numbers in this assay, from the lowest: compounds 3, 4, 1 and 2 (each within the scatter of the next, the first and the last beyond it).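

On the shared core, a 1.9-fold lower number from compound 1 to compound 4 (0.27 log units; within the scatter) in this assay, so this first single-place test on the carbonyl carbon shows that the larger 3-(piperidin-1-yl)prop-1-en-1-yl group, with its ring nitrogen, is accommodated without a step beyond the scatter. Nothing measured here explains this result.

Compound 3 differs from compound 4 in more than one place, so the effect of its tail cannot be separated from its other differences. A morpholine or dimethylamine on the same prop-1-en-1-yl chain remains an open question, as does the piperidinyl tail combined with the oxolan-3-yl ether of compound 2.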